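A 3,5-dimethylpiperazin-1-yl group on the sulfonyl sulfur

The compounds below may be only part of what the source reports. "The series", "measured", "known", "first", "only" and "open" are said of these compounds alone.

In a physicochemical assay for solubility, read by HPLC, using the shake flask method, measured as kinetic solubility, with a stated time of 20 h, at pH 6.5, tested at 200 uM (on this read-out lower numbers stand for lower solubility and higher numbers for higher solubility), compound 1 `C[C@@H](CO)NS(=O)(=O)c1cccc(-c2ccc3nccc(-c4ccncc4)c3n2)c1` gives 50000 nM. Compound 2 `CS(=O)(=O)c1cccc(-c2ccc3nccc(-c4ccncc4)c3n2)c1` gives < 5000 nM, which is a limit of the assay and not a number. Among the compounds with values here, the one measured step, an at least 10-fold lower number from compound 1 to compound 2 (1.00 log units; beyond the scatter), put methyl in place of (1-(hydroxymethyl)ethyl)amino on a sulfonyl sulfur. Compound 3 `C[C@@H]1CN(S(=O)(=O)c2cccc(-c3ccc4nccc(-c5ccncc5)c4n3)c2)C[C@H](C)N1` departs from compound 2 at that same place, with 3,5-dimethylpiperazin-1-yl in place of methyl on a sulfonyl sulfur. Here methyl leaves the sulfur instead of entering it. Going by that single step and by compound 1 at 50000 nM, a move to a higher number is expected in this assay, though one pair of compounds is thin support. The expected change is an at least 8.0-fold higher number from compound 2 to compound 3 (0.90 log units; beyond the scatter). For compound 3 the estimated value is 40000 nM, with an expected range from 8000 nM to 150000 nM.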

Compound 3, solubility: 180000 nM
Compound 3: middle estimate off by 4.5-fold (0.65 log units), on the low side; the whole stated range lies below it.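

In this assay, the sulfonyl sulfur now has a second nitrogen-linked group that reads well above methyl, this time a six-membered ring and not an open chain, with an at least 36-fold higher number from compound 2 to compound 3 (1.55 log units; beyond the scatter) in the new step. The size of that step is only a lower bound, since compound 2 stands at a limit of the assay and not at a number: the limit of < 5000 nM in this assay, at which 1 of the 3 values shown sits. The 3,5-dimethylpiperazin-1-yl group also goes past (1-(hydroxymethyl)ethyl)amino, with a 3.6-fold higher number from compound 1 to compound 3 (0.56 log units; beyond the scatter), so the number at this place had not reached its top with that chain.

From the compounds shown here alone, whether the ring itself or its two methyl groups carry this rise stays open. So does how an unsubstituted piperazine, a morpholine or a simple dimethylamino group on the same sulfur would read.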